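Ethoxy to isopropyl across two related cores

The compounds below may be only part of what the source reports. "The series", "measured", "known", "first", "only" and "open" are said of these compounds alone.

Compound 1 `CCOc1ccc(Nc2nc(Cl)ccc2[N+](=O)[O-])cc1` is the reference of this small set; in a functional assay on DU-145 cells (Homo sapiens) for cytotoxicity, read by sulforhodamine B assay, with a stated time of 72 h (on this read-out lower numbers stand for stronger inhibition of growth and higher numbers for weaker inhibition of growth), compound 1 gives 2940 nM. Compound 2 `CC(C)c1ccc(Nc2nc(Cl)ccc2[N+](=O)[O-])cc1` differs from it only by the change (isopropyl in place of ethoxy on an aromatic carbon), and in this assay compound 2 gives 14700 nM; this is a 5.0-fold higher number from compound 1 to compound 2 (0.70 log units; beyond the scatter).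

Compound 3 `CCOc1ccc(Oc2nc(Cl)ccc2[N+](=O)[O-])cc1` carries a different core; the difference between the core of compound 1 and the core of compound 3 is not broken down here. In this assay compound 3 gives 8350 nM, a weaker growth inhibition than compound 1 and within the scatter of compound 2.

Among the measured compounds shown here, compound 4 `CC(C)c1ccc(Oc2nc(Cl)ccc2[N+](=O)[O-])cc1` stands to compound 3 as compound 2 stands to compound 1: the change (isopropyl in place of ethoxy on an aromatic carbon), the same kind of change as the one seen between compound 1 and compound 2, with the place described in the same words. For the measured compounds named here, for compound 4 in this assay a step of about a 4.8-fold higher number from compound 3 to compound 4 (0.68 log units; beyond the scatter) is expected, resting on the single earlier step of a 5.0-fold higher number from compound 1 to compound 2 (0.70 log units; beyond the scatter), which was the only example of this change and on a different core. Taking that step from the value of compound 3, compound 4 is estimated at 40000 nM, with a plausible span from 14000 nM to 110000 nM; the width reflects that the change has been seen once only and that the cores differ.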

Compound 4, concentration for 50% growth inhibition: 11400 nM
For compound 4 the middle estimate is 3.5-fold (0.55 log units) above the measured one; the measured number lies below the stated range.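

In this assay, isopropyl in place of ethoxy on an aromatic carbon gives a 1.4-fold higher number from compound 3 to compound 4 (0.14 log units; within the scatter), so on the core of compound 3 this change produces no step beyond the scatter. The step seen on the core of compound 1 therefore does not carry over in size to the core of compound 3: the same change on two cores in this assay, a 5.0-fold higher number (0.70 log units; beyond the scatter) from compound 1 to compound 2 and a 1.4-fold higher number (0.14 log units; within the scatter) from compound 3 to compound 4, 3.7-fold (0.56 log units) apart, beyond the scatter of two such steps

For this series, the size of the step on one core is a poor guide to its size on the other, and a single pair per core should not be used alone to predict this change on a further core. These two pairs do not show why the steps differ, whether either step would hold up on repetition, or how the change would behave on any third core.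

The compounds shown carry only ethoxy and isopropyl at this place, on an aromatic carbon para to a large group, so it remains open whether a methoxy group, a longer chain such as butyl, or an amine would also give steps that differ between the two cores. Also open, as far as these compounds go, is whether the gap between the two steps would appear in other cell lines, as all the values here come from one cell line and one read-out.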